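Methylpiperazinyl benzoxazoles: methoxy to amino at a ring carbon

The source may report more compounds than this note shows. Statements on the series, on what has been measured and on what is new or still open speak of the compounds shown alone.

Measured so far:
compound 1 `COc1ccc2oc(N3CCN(C)CC3)nc2c1` — 4.78
compound 2 `Cc1cc(Cl)cc2nc(N3CCN(C)CC3)oc12` — 6.7

In a functional assay on ileum (strain Hartley) for agonist activity at 5-hydroxytryptamine receptor 3A (Cavia porcellus) (on this read-out lower numbers stand for lower potency and higher numbers for higher potency (the scale is a negative logarithm)), compound 1 gives 4.78, the lower of the two numbers in hand. Within the data shown here, compound 2 differs from compound 1 in several places; in this assay compound 2 gives 6.7, a gap that lies beyond the usual scatter; no single-change step connects the two, so nothing is read from that pair about any one group.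

Compound 3 `CN1CCN(c2nc3cc(N)ccc3o2)CC1` takes compound 1 as its starting point with one change: amino in place of methoxy on an aromatic carbon. Among the measured compounds shown here, no measured step of this kind exists, so the expected step of a number 0.22 log units higher from compound 1 to compound 3 (within the scatter) is set near zero, with a wide range, and is as likely to fall within the scatter as outside it. For compound 3 the estimate in this assay is 5, ranging from 4.3 to 5.9.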

Compound 3, negative logarithm of the half-maximal effective concentration: 4.97
Estimate against measurement, compound 3: 0.03 log units above; measured number inside the range.
By their numbers in this assay, from the lowest: compounds 1 and 3 (each within the scatter of the next); then compound 2.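

In this assay, among these compounds, amino in place of methoxy gives a number 0.19 log units higher from compound 1 to compound 3 (within the scatter) and is the first single-change step. At this aromatic carbon, meta to a fused ring and para to a fused ring, the two groups read alike despite differing in heavy atoms and hydrogen-bond donors. This position therefore tolerates this exchange without a change beyond the scatter, at least for this pair. No supporting measurement bears on why the pair reads this way.

As far as these compounds go, whether a carboxylic acid or an acetamide at this carbon would leave the number equally unmoved remains open. Which of the several differences in compound 2 goes with its 6.7 also stays unresolved, since no single-change step links it to compound 1 or compound 3.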